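Chloro on the anilide ring in two thioester series

A few compounds are considered here, and "the series" means these few. Any claim that something is new, unique, unknown or untested is made for them only; others in the source may bear on it.

Measured compounds:
compound 1, `CC(=O)SCCC(CCCCC(=O)Nc1ccccc1)SC(C)=O`, 1.68%
compound 2, `CC(=O)SCCC(CCCCC(=O)Nc1cccc(Cl)c1)SC(C)=O`, 0.04%
compound 3, `O=C(CCCCC(CCSC(=O)c1ccccc1)SC(=O)c1ccccc1)Nc1ccccc1`, "not active" (no number reported), without a number

All three were tested in a functional assay on KB cells (Homo sapiens) for inhibition, read by MTT assay, with a stated time of 24 h, tested at 1 ug/mL; on this read-out higher numbers stand for more inhibition of growth at the one concentration tested and lower numbers for less inhibition of growth. Compound 1 gives 1.68% and compound 2 gives 0.04%, both very low. The step of a number 1.6 percentage points lower from compound 1 to compound 2 (within the scatter) is the change (chloro in place of hydrogen on an aromatic carbon). For compound 3, the assay reported no number, only "not active" (no number reported).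

Compound 4, `O=C(CCCCC(CCSC(=O)c1ccccc1)SC(=O)c1ccccc1)Nc1ccccc1Cl`, has not been measured. It differs from compound 3 by chloro in place of hydrogen on an aromatic carbon. This is the same kind of change as the one from compound 1 to compound 2, and it occurs twice among the compounds shown; yet the place is not identical, since in the earlier pair the chloro sits meta to a large group and here it sits ortho to a large group. How the core of compound 3 differs from the core of compound 1 is not broken down here.

The expectation rests on two points. The step of a number 1.6 percentage points lower from compound 1 to compound 2 (within the scatter) shows that adding chloro to the anilide ring gave no change beyond the scatter. Compound 3, the direct parent, was reported inactive. Compound 4 is therefore expected to show very little growth inhibition in this assay, around 2%, with a range estimated from 0% to 12%, and there is a fair chance it is again reported only as inactive.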

Compound 4, percent growth inhibition at one concentration: 3.05%
Estimate against measurement, compound 4: 1.1 percentage points below; the range from low to high includes it.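

In this assay, within the data shown here, compound 4 gives 3.05% while compound 3 is reported only as "not active" without a number, so no step from compound 3 to compound 4 can be read. Nothing shown here offers an explanation for the result of compound 4. The compounds shown leave open whether chloro in place of hydrogen changes growth inhibition on the core of compound 3.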